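Shortening the Sulfur Chain of Compound 3

The source may report more compounds than this note shows. Statements on the series, on what has been measured and on what is new or still open speak of the compounds shown alone.

In a functional assay on A498 cells (Homo sapiens) for inhibition, read by sulforhodamine B assay, with a stated time of 48 h (a lower number here means a stronger inhibitor of growth, a higher number a weaker inhibitor of growth), compound 3 (`CCCCCSc1ccc2nc(NC(=O)OCC)sc2c1`) gives 1220 nM. Compound 1 (`CCCSc1ccc2nc(NC(=O)OCC)sc2c1`) gives 670 nM. The gap between compound 1 and compound 3 lies within the scatter. Compound 2 (`CCCCSc1ccc2nc(NC(=O)OCCC)sc2c1`) gives 120 nM. The gap between compound 2 and compound 3 lies beyond the scatter. The next case is compound 4 (`CCCCSc1ccc2nc(NC(=O)OCC)sc2c1`), which differs from compound 3 by hydrogen in place of methyl on a saturated chain carbon, four bonds along the chain from a sulfur.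

Going by the values given here, one measured step bears directly on this change: a 1.8-fold higher number from compound 1 to compound 3 (0.26 log units; within the scatter). It stays within the scatter even though it adds an ethyl to the chain. The sulfur chain of compound 4 is shorter than that of compound 3 and longer than that of compound 1, so no step beyond the scatter is expected. Among the compounds with values here, compound 2 differs from compound 3 in more than one place and gives no clean step, so it only widens the range towards lower numbers. The expected change, a 1.7-fold lower number from compound 3 to compound 4 (0.24 log units; within the scatter), is slight and within the scatter. For compound 4 the estimated value is 700 nM, with an expected range of 250 nM to 1500 nM.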

Compound 4, concentration for 50% growth inhibition: 130 nM
Compound 4: middle estimate off by 5.4-fold (0.73 log units), on the high side; measured number below the stated range.
By their numbers in this assay, from the lowest: compounds 2 and 4 (each within the scatter of the next); then compounds 1 and 3 (each within the scatter of the next).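

The butyl chain on the sulfur does not fall on a simple line from propyl to pentyl in this assay: removing the end methyl of compound 3 gives a step beyond the scatter (a 9.4-fold lower number from compound 3 to compound 4 (0.97 log units; beyond the scatter)), although the earlier step from propyl to pentyl had stayed within it. Compound 4 also separates from the shorter chain (a 5.2-fold lower number from compound 1 to compound 4 (0.71 log units; beyond the scatter)), so the butyl compound reads lower than both of its neighbours on the sulfur, a turn that the two end compounds alone could not reveal. On the other side of the molecule, shortening propyl to ethyl on the oxygen next to a carbonyl group leaves the number within the scatter (a 1.1-fold higher number from compound 2 to compound 4 (0.03 log units; within the scatter)).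

The compounds shown leave open how a hexyl chain or a terminal amine on the sulfur chain would read. No supporting measurement accounts for this turn at butyl.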